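The compounds below may be only part of what the source reports. "The series", "measured", "known", "first", "only" and "open" are said of these compounds alone.

Of the compounds shown here, three sharing one core have been measured in a functional assay on SK-BR-3 cells (Homo sapiens) for cytotoxicity, read by MTT assay, with a stated time of 72 h; on this read-out lower numbers stand for an effect already at smaller amounts and higher numbers for an effect only at larger amounts of compound. Compound 1 `COc1ccc(Nc2cc(C3CCCCC3)oc(=O)c2)cc1` gives 5.29 uM. Compound 2 `CCCCCc1cc(Nc2ccc(OC)cc2)cc(=O)o1` gives 4.93 uM in this assay. Compound 3 `COc1ccc(Nc2cc(-c3ccco3)oc(=O)c2)cc1` gives 1.76 uM in this assay, the lowest of the three numbers. The step of a 3.0-fold lower number from compound 1 to compound 3 (0.48 log units; beyond the scatter) and the step of a 2.8-fold lower number from compound 2 to compound 3 (0.45 log units; beyond the scatter) both go beyond the scatter, whereas the step of a 1.1-fold lower number from compound 1 to compound 2 (0.03 log units; within the scatter) stays within it. Compound 4 `COc1ccc(Nc2cc(C(C)C)oc(=O)c2)cc1` has not yet been measured; it differs from compound 3 by isopropyl in place of furan-2-yl on an aromatic carbon. Among the compounds with values here, the steps that bear on this change are the two that led to compound 3, read backwards: removing furan-2-yl in favour of a group without a ring, as in a 2.8-fold lower number from compound 2 to compound 3 (0.45 log units; beyond the scatter) reversed, has so far gone with a modestly higher number, and the two groups without a furan ring, in compound 1 and compound 2, gave numbers within the scatter of each other. The step of a 2.8-fold higher number from compound 3 to compound 4 (0.45 log units; beyond the scatter) is therefore expected to be a modest rise. Compound 4 is estimated at 5 uM in this assay, with a range from 2.5 uM to 10 uM.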

Compound 4, concentration for half-maximal effect: > 30 uM
Compound 4: no number, only a limit (the forecaster's own chance of this, stated with the estimate: 5%); middle value at least 6.0-fold (0.77 log units) away from the limit.
By their numbers in this assay, from the lowest: compound 3; then compounds 2 and 1 (each within the scatter of the next). At a limit, above all of these: compound 4.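

Compound 4 gives only a limit of the assay in this assay, not a number: > 30 uM. This position, next to the ring oxygen, proves more sensitive than compound 1 and compound 2 suggested, since their cyclohexyl and pentyl groups lay within the scatter of each other, whereas isopropyl gives an at least 5.6-fold higher number from compound 1 to compound 4 (0.75 log units; beyond the scatter) and an at least 6.0-fold higher number from compound 2 to compound 4 (0.78 log units; beyond the scatter). Loss of furan-2-yl in favour of isopropyl gives an at least 17-fold higher number from compound 3 to compound 4 (1.23 log units; beyond the scatter), the largest step at this position so far, and having no ring does not by itself explain it, as pentyl also has none and stays far closer to compound 3.

From the compounds shown here alone, how far compound 4 truly lies from the others stays unknown, as its limit sets only a minimum for each step. Also open, going by these compounds, is where a butyl chain, a cyclopropyl ring or a thiophene ring would fall at this position.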